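A few compounds are considered here, and "the series" means these few. Any claim that something is new, unique, unknown or untested is made for them only; others in the source may bear on it.

Working notes on the series. Compound 1 `O=C(OC(C(F)(F)F)C(F)(F)F)N1CCN(Cc2ccc(C(F)(F)F)cc2N2CCCCC2)CC1` serves as the reference; in an assay on brain for inhibition of Monoglyceride lipase (Mus musculus), with a stated time of 30 min (on this read-out higher numbers stand for weaker inhibition and lower numbers for stronger inhibition), compound 1 gives 130 nM. Compound 2 `O=C(OC(C(F)(F)F)C(F)(F)F)N1CCN(Cc2ccc(Cl)cc2N2CC[C@H]3CCCN3C2)CC1`, measured in this assay, gives 66 nM, and the two numbers lie within the scatter of one another, so neither stands apart. Compound 3 `O=C(OC(C(F)(F)F)C(F)(F)F)N1CCN(Cc2ccc(C(F)(F)F)cc2N2CC[C@H](O)C2)CC1` is unmeasured and differs from compound 1 by 3-hydroxypyrrolidin-1-yl in place of piperidin-1-yl on an aromatic carbon. Among the compounds with values here, no measured pair shows this change; the step is expected to be small, leaning toward a higher number, as a 1.5-fold higher number from compound 1 to compound 3 (0.19 log units; within the scatter). Compound 3 is therefore expected to give 200 nM in this assay, within 70 nM to 600 nM.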

Compound 3, half-maximal inhibitory concentration: 15 nM
Beside the measured number, compound 3's estimate is 13-fold (1.12 log units) above it; the measured number lies below the stated range.
By their numbers in this assay, from the lowest: compound 3; then compounds 2 and 1 (each within the scatter of the next).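

In this assay, within the data shown here, 3-hydroxypyrrolidin-1-yl in place of piperidin-1-yl on an aromatic carbon gives an 8.7-fold lower number from compound 1 to compound 3 (0.94 log units; beyond the scatter), so the group at this place can move the number beyond the scatter, which the earlier compounds, differing in more than one place, could not show. The change alters ring size and adds a hydroxyl group in a single step, and the two are not separated here. Nothing at hand bears on the cause of this step.

Open, from the compounds shown here alone, is how unsubstituted pyrrolidin-1-yl and 4-hydroxypiperidin-1-yl would compare at this place. Also open, going by these compounds, is the opposite stereocentre of the 3-hydroxypyrrolidin-1-yl group.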